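Chain Amine Replaces Cyclic Amine on a Shared Core

The source may report more compounds than this note shows. Statements on the series, on what has been measured and on what is new or still open speak of the compounds shown alone.

Compound 1 `Cc1cc2c(c(N)nn2C)c(N2CCCCC2)n1` and compound 2 `Cc1cc2c(c(N)nn2C)c(N2CC[C@H](O)C2)n1` share one core and differ only in the group on an aromatic carbon. In an assay on isolated protein for inhibition of ribosomal protein S6 kinase alpha-5 (Homo sapiens), read by mobility shift assay, tested at 30 uM (a lower number here means less inhibition, a higher number more inhibition at the concentration tested (going by the name of the read-out)), compound 1 gives 7% and compound 2 gives 4%, so the two numbers sit within the scatter of each other and neither compound separates from the other. Compound 3 `COCCNc1nc(C)cc2c1c(N)nn2C` carries (2-methoxyethyl)amino in place of 3-hydroxypyrrolidin-1-yl on an aromatic carbon. Among the measured compounds shown here, no measured step covers this exchange; the only step available, a number 3 percentage points lower from compound 1 to compound 2 (within the scatter), left the number essentially unchanged, and both measured values sit close to zero. Compound 3 is therefore expected to stay low, with an estimated step of a number 1 percentage points higher from compound 2 to compound 3 (within the scatter) and a value near 5%, in a range from -5% to 15%.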

Compound 3, a percentage reported as inhibition, at one concentration (the size of the read-out at that concentration, not a potency): 0%
For compound 3 the middle estimate is 5 percentage points above the measured one; measured number inside the range.
By their numbers in this assay, from the lowest: compounds 3, 2 and 1 (each within the scatter of the next).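

In this assay, a chain with no ring at this aromatic carbon cannot be told apart from either cyclic amine: the exchange for 3-hydroxypyrrolidin-1-yl gives a number 4 percentage points lower from compound 2 to compound 3 (within the scatter), and the exchange for piperidin-1-yl gives a number 7 percentage points lower from compound 1 to compound 3 (within the scatter). So at this position, neither the ring nor the defined stereocentre of compound 2 is needed to stay within the scatter. Nothing available explains this reading.

From the compounds shown here alone, it remains open whether any group here can lift the number clear of the scatter. A carboxylic acid or a longer alkyl chain in this place would test that.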